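The compounds below may be only part of what the source reports. "The series", "measured", "known", "first", "only" and "open" are said of these compounds alone.

Measured so far in an ADME assay on MRC5 cells (Homo sapiens), read by MTT assay, with a stated time of 72 h; on this read-out lower numbers stand for stronger inhibition and higher numbers for weaker inhibition:
- compound 1 `CNc1ncnc2c1c(-c1ccco1)cn2[C@@H]1O[C@H](CO)[C@@H](O)[C@H]1O` gives 90800 nM
- compound 2 `CN(C)c1ncnc2c1c(-c1cc3ccccc3o1)cn2[C@@H]1O[C@H](CO)[C@@H](O)[C@H]1O` gives > 100000 nM as a limit

Among the compounds with values here, compound 1 holds the only numeric value. Compound 2 reports only the limit > 100000 nM in this assay.

Compound 3 `CNc1ncnc2c1c(I)cn2[C@@H]1O[C@H](CO)[C@@H](O)[C@H]1O` is unmeasured and carries iodo in place of furan-2-yl on an aromatic carbon, with iodo in place of furan-2-yl on an aromatic carbon as the full change. No measured step sizes this change in this assay, so only a moderate shift toward stronger inhibition is expected, with a wide margin. The expected change is a 2.3-fold lower number from compound 1 to compound 3 (0.36 log units; beyond the scatter) on this estimate. Compound 3 is estimated at 40000 nM in a range of 5000 nM to 100000 nM here.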

Compound 3, half-maximal inhibitory concentration: > 100000 nM
Compound 3 gave a limit, no number; the forecaster's own chance of this, stated with the estimate: 30%; middle value at least 2.5-fold (0.39 log units) from the limit.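

In this assay compound 3 gives > 100000 nM, which is a limit and not a number. At this aromatic carbon, iodo in place of furan-2-yl brings no gain toward stronger inhibition, with an at least 1.1-fold higher number from compound 1 to compound 3 (0.04 log units; that floor lies within the scatter) as the step. The true size of the step stays unknown, because the read-out ends at a limit: the limit of > 100000 nM in this assay, at which 2 of the 3 values shown sit.

As far as these compounds go, whether an amine or a nitrile on this aromatic carbon would give a measurable number stays open. The same holds for a carboxylic acid or a longer chain there.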